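The source may report more compounds than this note shows. Statements on the series, on what has been measured and on what is new or still open speak of the compounds shown alone.

Among the compounds with values here, in a physicochemical assay for lipophilicity, measured as octanol-water partition (a higher number here means a more lipophilic compound, a lower number a more polar compound), compound 1 (`COC(=O)c1cn(C/C=C(/C)CC/C=C(\C)CCC=C(C)C)nn1`) gives 5.25, the second highest of the three numbers so far. Compound 2 (`CC(C)=CCC/C(C)=C/CC/C(C)=C/Cn1cc(-c2ccccc2)nn1`) stands higher at 6.95 and compound 3 (`CC(C)=CCC/C(C)=C/Cn1cc(-c2ccccc2)nn1`) lower at 4.91, both beyond the scatter from compound 1. Compound 4 (`CCCCCCCCc1cn(C/C=C(/C)CC/C=C(\C)CCC=C(C)C)nn1`) keeps the chain of compound 1 and differs at one place: octyl in place of methoxycarbonyl on an aromatic carbon.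

Within the data shown here, only one measured step bears on this, and only indirectly: a number 2.04 log units lower from compound 2 to compound 3 (beyond the scatter). It is large and beyond the scatter, but it concerns the loss of 3-methylbut-2-en-1-yl from the chain, not a change on the aromatic carbon. Among the measured compounds shown here, no measured step shows octyl or methoxycarbonyl being exchanged. Read in reverse, that step points to a large rise when carbon is added, and compound 2, with the same chain as compound 1, also lies well above it. A large upward step in this assay is therefore expected, estimated as a number 3.35 log units higher from compound 1 to compound 4 (beyond the scatter). The expected value for compound 4 is 8.6, with an estimated range of 7.6 to 9.5.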

Compound 4, partition coefficient: 8.76
Beside the measured number, compound 4's estimate is 0.16 log units below it; low and high end bracket the measured number.
By their numbers in this assay, from the lowest: compound 3; then compound 1; then compound 2; then compound 4.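

In this assay, within the data shown here, octyl in place of methoxycarbonyl on an aromatic carbon gives a number 3.51 log units higher from compound 1 to compound 4 (beyond the scatter) and is the first measured change at this position. With the chain held constant, this single exchange shows that the position can carry a large upward step, as large in this series as the change made on the chain. No independent data bear on why the step has this size.

One exchange leaves apart neither the added carbon count of octyl nor the loss of the 2 hydrogen-bond acceptors of methoxycarbonyl, so a butyl group or a longer chain on the same aromatic carbon would be needed to show how the number follows chain length. On these data alone, how an amine or a carboxylic acid at this position would stand against compound 1 also remains open.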